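Alkyne terminus variants: compound 4 on the shared core

This account rests on a few compounds, and the source may have more. Where it says the series, first, only, none or still open, it means among the compounds named here.

Measured so far in an assay on CHO cells for displacement of a labelled ligand from adenosine receptor A1 (Homo sapiens), read by scintillation counting, with a stated time of 60 min, tested at 10 uM; on this read-out higher numbers stand for more inhibition at the one concentration tested (going by the name of the read-out) and lower numbers for less inhibition:
compound 1 `CNC(=O)[C@@]12C[C@@H]1[C@@H](n1cnc3c(NC)nc(C#Cc4ccc(OC)cc4)nc31)[C@H](O)[C@@H]2O` gives 10%;
compound 2 `CNC(=O)[C@@]12C[C@@H]1[C@@H](n1cnc3c(NC)nc(C#Cc4cccc(C(F)(F)F)c4)nc31)[C@H](O)[C@@H]2O` gives 10%;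
compound 3 `CCc1ccc(C#Cc2nc(NC)c3ncn([C@H]4[C@H](O)[C@H](O)[C@]5(C(=O)NC)C[C@H]45)c3n2)o1` gives 18%.

Compound 3 carries the largest reading of the three only numerically: a number 8 percentage points higher from compound 1 to compound 3 (within the scatter) and a number 8 percentage points higher from compound 2 to compound 3 (within the scatter), both within the scatter, as is no change at the digits printed from compound 1 to compound 2 (within the scatter). Every measured step swaps one aryl or heteroaryl group for another on the triple-bonded carbon, and none moves the reading beyond the scatter.

Compound 4 `CNC(=O)[C@@]12C[C@@H]1[C@@H](n1cnc3c(NC)nc(C#CC4CC4)nc31)[C@H](O)[C@@H]2O` differs from compound 3 thus: cyclopropyl in place of 5-ethylfuran-2-yl on a triple-bonded carbon. Among the compounds with values here, no measured step covers a non-aromatic group at this place, so the three aryl swaps are the only guide. On that basis the expected step is a number 6 percentage points lower from compound 3 to compound 4 (within the scatter), no change beyond the scatter. Compound 4 is estimated at 12%, within 0% to 28%.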

Compound 4, a percentage reported as inhibition, at one concentration (the size of the read-out at that concentration, not a potency): 38%
The estimate for compound 4 lay 26 percentage points below the measured number, and the stated range ends below it.
By their numbers in this assay, from the lowest: compounds 1, 2 and 3 (each within the scatter of the next); then compound 4.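

Within the data shown here, at the triple-bonded carbon, cyclopropyl is the first group to move the reading in this assay beyond the scatter, with a number 20 percentage points higher from compound 3 to compound 4 (beyond the scatter) and a number 28 percentage points higher from compound 2 to compound 4 (beyond the scatter) and a number 28 percentage points higher from compound 1 to compound 4 (beyond the scatter) as its steps. The 4-methoxyphenyl, 3-(trifluoromethyl)phenyl and 5-ethylfuran-2-yl groups remain within the scatter of one another, so the only separation at this place lies between them and cyclopropyl. Nothing measured here accounts for this step.

With one non-aromatic group shown, it remains open whether the higher reading is specific to cyclopropyl. A cyclobutyl ring, a straight propyl chain or an aminomethyl group at this place would test that.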